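Replacing the ethoxypyridinyl arm of compound 2 with trifluoromethylphenyl

The source may hold more compounds than are shown below. What is called first, only, known or untested is meant among the compounds shown, and "the series" means these compounds.

Of the compounds shown here, three sharing one core have been measured in a functional assay on BJAB cells (Homo sapiens) for antiproliferative activity, with a stated time of 4 days; on this read-out higher numbers stand for an effect only at larger amounts of compound and lower numbers for an effect already at smaller amounts. Compound 1 `CCSc1sc(-n2nc(C)c(Cc3ccccc3[N+](=O)[O-])c2C(=O)O)nc1-c1ccc(Cl)c(Cl)c1` gives 59000 nM in this assay. For the measured compounds named here, compound 3 `CCSc1sc(-n2nc(C)c(Cc3ccccc3[N+](=O)[O-])c2C(=O)OC)nc1-c1ccc(Cl)c(Cl)c1`, its methyl ester, gives 106000 nM, and the only single-point step among the measured compounds, a 1.8-fold higher number from compound 1 to compound 3 (0.25 log units; within the scatter), therefore tells nothing about changes to the aromatic arm on the core. Compound 2 `CCOc1ncccc1-c1c(C)nn(-c2nc(-c3ccc(Cl)c(Cl)c3)c(SC(C)C)s2)c1C(=O)O` gives 11000 nM and stands lowest of the three numbers, with both compound 1 and compound 3 beyond the scatter from it.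

Compound 4 `Cc1nn(-c2nc(-c3ccc(Cl)c(Cl)c3)c(SC(C)C)s2)c(C(=O)O)c1-c1ccc(C(F)(F)F)cc1`, not yet measured, differs from compound 2 by 4-(trifluoromethyl)phenyl in place of 2-ethoxypyridin-3-yl on an aromatic carbon. Going by the values given here, no measured pair isolates a change at this position, so the step from compound 1 to compound 3 does not bear on it, and the expectation rests only on compound 2 holding the lowest number among the three. The direction of the step is open; a move of moderate size in either direction in this assay would not be surprising.

Compound 4 is therefore estimated at 15000 nM, with a range from 4000 nM to 55000 nM. That estimate means a step of a 1.4-fold higher number from compound 2 to compound 4 (0.13 log units; within the scatter), expected to stay close to the number of compound 2.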

Compound 4, half-maximal effective concentration: 3500 nM
For compound 4 the middle estimate is 4.3-fold (0.63 log units) above the measured one; measured number below the stated range.
By their numbers in this assay, from the lowest: compound 4; then compound 2; then compounds 1 and 3 (each within the scatter of the next).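

In this assay, the exchange of 2-ethoxypyridin-3-yl for 4-(trifluoromethyl)phenyl gives a 3.1-fold lower number from compound 2 to compound 4 (0.50 log units; beyond the scatter), the first step among the compounds shown that reads a change at this aromatic carbon, and it lies beyond the scatter. The position next to the ring atom that bears a carboxy group therefore responds to the choice of arm, and neither the ring nitrogen nor the ethoxy group of the leaving arm is required for a number at the level of compound 2 or lower. No measurement among the data shown bears on why the number moves.

The step replaces the ring nitrogen, the ethoxy group and the trifluoromethyl group in a single exchange, so it does not tell which of these changes goes with the lower number, and a plain phenyl arm or a pyridinyl arm without the ethoxy group would separate them. Going by these compounds, it also remains open whether a methyl ester in place of the carboxylic acid would behave with this arm as it does in the step of a 1.8-fold higher number from compound 1 to compound 3 (0.25 log units; within the scatter), which lies within the scatter.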